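A few compounds are considered here, and "the series" means these few. Any claim that something is new, unique, unknown or untested is made for them only; others in the source may bear on it.

Among the measured compounds shown here, compound 1 `CC(C)CCOC(=O)OCC(CO)CCn1cnc2cnc(N)nc21` stands highest of the two numbers measured so far: in an ADME assay for pharmacokinetics, read by HPLC, at 37 degrees C, at pH 1.2 (a lower number here means that the compound disappears faster, a higher number that the compound lasts longer), compound 1 gives 576 h. Compound 2 `COC(=O)OCC(CO)CCn1cnc2cnc(N)nc21` gives 552 h in this assay, and the step of a 1.0-fold lower number from compound 1 to compound 2 (0.02 log units; within the scatter) shows that removing most of the chain on that side of the carbonate left the number where it was. Compound 3 `CCCCOC(=O)OCC(CO)CCn1cnc2cnc(N)nc21` differs from compound 1 by a smaller trimming of the same chain: hydrogen in place of methyl on a saturated chain carbon bound to two saturated chain carbons. For the measured compounds named here, the only step that bears on it was within the scatter, so no step beyond the scatter is expected in this assay. Compound 3 is therefore expected to give 565 h, between 350 h and 900 h, a step of a 1.0-fold lower number from compound 1 to compound 3 (0.01 log units; within the scatter).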

Compound 3, half-life: 696 h
Compound 3: the middle estimate sits 1.2-fold (0.09 log units) below what was measured; measured number inside the range.
By their numbers in this assay, from the lowest: compounds 2, 1 and 3 (each within the scatter of the next).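

In this assay, the branch in the chain does not show up as a real difference: going from isopentyl to butyl gives (a 1.2-fold higher number from compound 1 to compound 3 (0.08 log units; within the scatter)). The unbranched chain tells the same story for length, with propyl in place of hydrogen giving (a 1.3-fold higher number from compound 2 to compound 3 (0.10 log units; within the scatter)), so neither the branch nor the chain length moves the number beyond the scatter in these three compounds. Nothing measured here offers an explanation for these numbers.

All three compounds carry a plain saturated chain on the carbonate. As far as these compounds go, whether an amine, a carboxylic acid or a phenyl ring on that chain would shift the number remains open.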